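Adding a methyl to the anilino ring of compound 3

This account rests on a few compounds, and the source may have more. Where it says the series, first, only, none or still open, it means among the compounds named here.

In an ADME assay on MT4 cells (Homo sapiens) for cytotoxicity, read by MTT assay (a higher number here means that more compound is tolerated, a lower number that less compound is tolerated), compound 3 `O=C(CSc1nncnc1-c1ccccc1Cl)Nc1ccccc1` gives 127000 nM and stands highest of the three measured, with compound 1 `O=C(CSc1nncnc1-c1ccccc1Cl)c1ccc(Cl)c(Cl)c1` at 33000 nM and compound 2 `O=C(CSc1nncnc1-c1ccccc1Cl)c1ccc(Br)cc1Br` at 28000 nM as the lower pair. Compound 4 `Cc1ccccc1NC(=O)CSc1nncnc1-c1ccccc1Cl` has methyl in place of hydrogen on an aromatic carbon, ortho to a large group methyl in place of hydrogen on an aromatic carbon and thus phenyl to 2-methylphenyl. Among the measured compounds shown here, no measured step tests this change. The nearest steps replace the whole group on the carbonyl carbon: a 3.8-fold higher number from compound 1 to compound 3 (0.59 log units; beyond the scatter) and a 4.5-fold higher number from compound 2 to compound 3 (0.66 log units; beyond the scatter) are modest, and a 1.2-fold lower number from compound 1 to compound 2 (0.07 log units; within the scatter) stays within the scatter. A far smaller change is therefore expected to give a small step toward lower numbers, estimated as a 1.3-fold lower number from compound 3 to compound 4 (0.10 log units; within the scatter) and not beyond the scatter. Compound 4 is estimated at 100000 nM with an expected range from 50000 nM to 190000 nM in this series.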

Compound 4, half-maximal cytotoxic concentration: 142000 nM
The estimate for compound 4 lay 1.4-fold (0.15 log units) below the measured number; measured number inside the range.
By their numbers in this assay, from the lowest: compounds 2 and 1 (each within the scatter of the next); then compounds 3 and 4 (each within the scatter of the next).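

In this assay, methyl in place of hydrogen on an aromatic carbon, ortho to a large group, gives a step within the scatter (a 1.1-fold higher number from compound 3 to compound 4 (0.05 log units; within the scatter)), so the hydrogen of compound 3 can give way to methyl here with no readable shift. With (2-methylphenyl)amino on the carbonyl carbon, the modest gaps to the aryl compounds remain (a 5.1-fold higher number from compound 2 to compound 4 (0.71 log units; beyond the scatter); a 4.3-fold higher number from compound 1 to compound 4 (0.63 log units; beyond the scatter)). No measured evidence bears on why this step is so small.

Open, on these data alone, is whether an ethyl, a methoxy or a carboxylic acid at this place would also stay within the scatter of compound 3.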